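The source may report more compounds than this note shows. Statements on the series, on what has been measured and on what is new or still open speak of the compounds shown alone.

Measured in a functional assay on MDA-MB-231 cells (Homo sapiens) for inhibition, read by MTT assay, with stated times of 18 h and 4 h; on this read-out lower numbers stand for stronger inhibition and higher numbers for weaker inhibition:
- compound 1 `CCCCCCCCCCOP(=O)(O)OCCSC(=S)N1CCCCCC1`: 11400 nM
- compound 2 `CCCCCCCCOP(=O)(O)OCCSC(=S)N1CCCCC1`: 11900 nM
- compound 3 `CCCCCCCCOP(=O)(O)OCCSC(=S)N1CCN(C)CC1`: 58500 nM

Compound 1 sits within the usual scatter of compound 2, so these two cannot be ranked. Compound 3 gives a clearly higher number than either, which means weaker inhibition.

The next compound to be tested is compound 4 `CCCCCCCCCCOP(=O)(O)OCCSC(=S)N1CCCCC1`. It keeps the decyl chain and the shared core of compound 1, and the change is confined to one group on a thiocarbonyl carbon: piperidin-1-yl in place of azepan-1-yl on a thiocarbonyl carbon.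

For the measured compounds named here, no measured pair shows this exact swap. Going by the values given here, the only measured step, a 4.9-fold higher number from compound 2 to compound 3 (0.69 log units; beyond the scatter), is modest and replaces piperidin-1-yl with a different ring, so it shows that this group can matter. It does not give the size of the change from azepan-1-yl. The closer clue is compound 2, which already carries piperidin-1-yl on an octyl chain and gives 11900 nM, alongside compound 1 at 11400 nM.

Neither ring type therefore stands apart so far, and no shift beyond the scatter is expected in this assay. The expected change is a 1.0-fold lower number from compound 1 to compound 4 (0.02 log units; within the scatter), with no firm direction. For compound 4 the estimated value is 11000 nM, with an expected range from 5000 nM to 24000 nM.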

Compound 4, half-maximal inhibitory concentration: 24600 nM
Compound 4: middle estimate off by 2.2-fold (0.35 log units), on the low side; measured number outside the range, above it.
By their numbers in this assay, from the lowest: compounds 1 and 2 (each within the scatter of the next); then compound 4; then compound 3.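

In this assay, the ring on the thiocarbonyl carbon matters even when the decyl chain is held fixed: putting piperidin-1-yl in place of azepan-1-yl gives a 2.2-fold higher number from compound 1 to compound 4 (0.33 log units; beyond the scatter), which means weaker inhibition. The chain matters too, since with piperidin-1-yl held fixed, going from the octyl chain to the decyl chain gives a 2.1-fold higher number from compound 2 to compound 4 (0.32 log units; beyond the scatter), again weaker inhibition and a step of similar size. Both steps are modest but beyond the scatter, yet nothing measured here explains why either change moves the number.

The compounds shown leave open whether azepan-1-yl would also give a lower number than piperidin-1-yl on the octyl chain, so the ring step is known on the decyl chain alone. They also leave open how a smaller ring such as pyrrolidin-1-yl or an open-chain group such as diethylamino would behave on the thiocarbonyl carbon, and whether a longer chain such as dodecyl would continue the rise seen from octyl to decyl.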